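Methyl Ortho to Acetamido: What Compound 4 May Give

The compounds below may be only part of what the source reports. "The series", "measured", "known", "first", "only" and "open" are said of these compounds alone.

Compound 1 `NS(=O)(=O)c1ccc(S(=O)(=O)Nc2cccc(-c3nc(-c4ccc(NC(=O)c5cccnc5)cc4Cl)no3)c2)cc1` in a functional assay on MDA-MB-231 cells (Homo sapiens) for antiproliferative activity, read by MTT assay, with a stated time of 72 h (on this read-out lower numbers stand for stronger inhibition and higher numbers for weaker inhibition), gives > 10000 nM, a limit of the assay. Compound 2 `O=C(Nc1ccc(-c2noc(-c3cccc(NS(=O)(=O)c4ccc(C(F)(F)F)cc4)c3)n2)c(Cl)c1)c1cccnc1` gives > 10000 nM, also a limit. Compound 3 `CC(=O)Nc1ccc(S(=O)(=O)Nc2cccc(-c3nc(-c4ccc(NC(=O)c5cccnc5)cc4Cl)no3)c2)cc1` gives 2500 nM.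

Going by the values given here, compound 3 is thus the only one with a number, the other two sitting at the limit of > 10000 nM in this assay, at which 2 of the 3 values shown sit. Replacing sulfamoyl or trifluoromethyl by acetamido gave an at least 4.0-fold lower number from compound 1 to compound 3 (0.60 log units; beyond the scatter) and an at least 4.0-fold lower number from compound 2 to compound 3 (0.60 log units; beyond the scatter). Compound 4 `CC(=O)Nc1ccc(S(=O)(=O)Nc2cccc(-c3nc(-c4ccc(NC(=O)c5cccnc5)cc4Cl)no3)c2)cc1C` keeps the acetamido and differs from compound 3 only by methyl in place of hydrogen on an aromatic carbon. Among the compounds with values here, no measured step touches a methyl at this place, so no step beyond the scatter is expected: no change at the digits printed from compound 3 to compound 4 (within the scatter). Compound 4 is therefore estimated at 2500 nM, between 800 nM and 8000 nM.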

Compound 4, half-maximal inhibitory concentration: > 10000 nM
Compound 4 gave a limit, no number; the forecaster's own chance of this, stated with the estimate: 20%; at least 4.0-fold (0.60 log units) between middle value and limit.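

In this assay, methyl in place of hydrogen, ortho to the acetamido group, gives an at least 4.0-fold higher number from compound 3 to compound 4 (0.60 log units; beyond the scatter), a step that rests on a limit for compound 4 and not on a number. Keeping the acetamido is therefore not enough on its own: this single added carbon removes the only number the earlier compounds had given. The steps from compound 1 and compound 2 to compound 4 cannot be read, because both ends of each are limits: the limit of > 10000 nM in this assay, at which 3 of the 4 values shown sit.

From the compounds shown here alone, how weak compound 4 really is stays open. Also open, going by these compounds, is whether a fluorine atom, a methoxy group or an amine at this same place would keep a number.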